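This account rests on a few compounds, and the source may have more. Where it says the series, first, only, none or still open, it means among the compounds named here.

Measured compounds and their values:

compound 1, `O=C(Nc1ccc(Cl)cc1)C1CCCN(C(=O)c2cccc(-c3ccco3)c2)C1`: in an ADME assay on PC-3 cells (Homo sapiens) for cytotoxicity, read by WST assay, tested at 100 uM (on this read-out lower numbers stand for less inhibition and higher numbers for more inhibition at the one concentration tested (going by the name of the read-out)), compound 1 gives 0%
compound 2, `Cc1cccc(C(=O)N2CCCC(C(=O)Nc3ccc(Cl)cc3)C2)c1`: compound 2 gives 0%
compound 3, `CS(=O)(=O)Nc1cccc(C(=O)N2CCCC(C(=O)Nc3ccc(Cl)cc3)C2)c1`: compound 3 gives 3%

All of them share one core and differ only in a single group on an aromatic carbon. Compound 3 has the highest of the three numbers, but its steps to the others are small: a number 3 percentage points higher from compound 1 to compound 3 (within the scatter) and a number 3 percentage points higher from compound 2 to compound 3 (within the scatter). The remaining pair behaves the same way, no change at the digits printed from compound 1 to compound 2 (within the scatter). In short, every measured compound sits at or near the bottom of the read-out, and no change at that aromatic carbon has moved the number beyond the scatter.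

Compound 4, `CC(C)(C)CC(=O)Nc1cccc(C(=O)N2CCCC(C(=O)Nc3ccc(Cl)cc3)C2)c1`, differs from compound 3 in one place: neopentylcarbonyl in place of methylsulfonyl on a nitrogen on an aromatic ring. Among the compounds with values here, no measured step alters this nitrogen, so none bears directly on it. What the measured steps do show is that the whole series, whatever group sits on that aromatic carbon, stays flat at the low end. On that basis the step to compound 4 is expected to be none beyond the scatter: no change at the digits printed from compound 3 to compound 4 (within the scatter). The expected value for compound 4 in this assay is 3%, with a range from -5% to 15%.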

Compound 4, a percentage reported as inhibition, at one concentration (the size of the read-out at that concentration, not a potency): 0%
Estimate against measurement, compound 4: 3 percentage points above; measured number inside the range.
By their numbers in this assay, from the lowest: compounds 1, 2, 4 and 3 (each within the scatter of the next).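

In this assay, the step that alters this nitrogen directly gives a number 3 percentage points lower from compound 3 to compound 4 (within the scatter). Here methylsulfonyl, with 4 heavy atoms and a sulfur, gives way to neopentylcarbonyl, with 7 heavy atoms and a single carbonyl oxygen, so this nitrogen on the aromatic ring can carry either group with no shift beyond the scatter at the one concentration tested. The new compound also extends the flat picture at the aromatic carbon, where (neopentylcarbonyl)amino gives no change at the digits printed from compound 2 to compound 4 (within the scatter) and no change at the digits printed from compound 1 to compound 4 (within the scatter), and the data shown hold no measurement that bears on why these numbers stay so close.

Going by these compounds, all four compounds sit at or near the bottom of the read-out, so it remains open whether any group at this aromatic carbon can raise the number beyond the scatter, for example a free amine or a carboxylic acid in place of the (neopentylcarbonyl)amino group. On these data alone, it also remains open whether a longer chain on the carbonyl attached to this nitrogen would stay as flat as neopentylcarbonyl does.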